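Swapping the aryl group on a thiourea nitrogen

This account rests on a few compounds, and the source may have more. Where it says the series, first, only, none or still open, it means among the compounds named here.

Compound 1 `NC(=O)c1c(NC(=O)c2ccccc2Cl)sc2c1CCN(Cc1ccccc1F)C2` — > 50000 nM, a limit of the assay.
Compound 2 `NC(=O)c1c(NC(=O)c2ccccc2Cl)sc2c1CCN(C(=S)Nc1ccccc1Br)C2` — 24600 nM.

In a functional assay on HeLa cells (Homo sapiens) for antiproliferative activity, with a stated time of 24 h (a higher number here means a weaker inhibitor, a lower number a stronger inhibitor), compound 2 gives 24600 nM. It is the only number shown, the other value being a limit. Compound 1 sits at a limit in this assay, namely (the limit of > 50000 nM in this assay, at which 1 of the 2 values shown sits). Within the data shown here, the one measured step, an at least 2.0-fold lower number from compound 1 to compound 2 (0.30 log units; that floor lies within the scatter), exchanges the benzyl-type substituent on the ring amine for a thiourea carrying a 2-bromophenyl group, and because compound 1 rests at the limit of > 50000 nM in this assay, at which 1 of the 2 values shown sits, the true size of that step is open.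

Compound 3 `NC(=O)c1c(NC(=O)c2ccccc2Cl)sc2c1CCN(C(=S)Nc1ccc(C(F)(F)F)cc1)C2` keeps the thiourea and differs from compound 2 only in the aryl group: 4-(trifluoromethyl)phenyl in place of 2-bromophenyl on an amide-type nitrogen. Among the measured compounds shown here, no measured step touches this position; the step from compound 1 to compound 2 changed a different part of the molecule, so it gives no direction for the present change. For the measured compounds named here, with the only number standing at 24600 nM for compound 2, a step near zero is expected for compound 3, a 1.0-fold higher number from compound 2 to compound 3 (0.01 log units; within the scatter), with wide uncertainty. Compound 3 is therefore estimated at 25000 nM, in the range 7000 nM to 60000 nM.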

Compound 3, half-maximal inhibitory concentration: > 50000 nM
Compound 3 gave a limit, no number (the forecaster's own chance of this, stated with the estimate: 30%); middle value at least 2.0-fold (0.30 log units) from the limit.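

Among these compounds, the aryl group on the thiourea nitrogen now has a measured step of its own in this assay, which the earlier compounds did not give: an at least 2.0-fold higher number from compound 2 to compound 3 (0.30 log units; that floor lies within the scatter). On these data alone, the printed floor of this step lies within the scatter, and its true size stays open because compound 3 rests at a limit and not at a number: the limit of > 50000 nM in this assay, at which 2 of the 3 values shown sit. The thiourea alone therefore does not secure a number in this assay, since compound 3 carries it with 4-(trifluoromethyl)phenyl on the amide-type nitrogen and still ends at a limit, leaving the 2-bromophenyl compound 2 as the only one of the three with a number.

As far as these compounds go, the two aryl groups differ both in the substituent and in where it sits on the ring, so it remains open which of these matters, and a 4-bromophenyl group on the same nitrogen would separate the two. Also open, from the compounds shown here alone, is how an unsubstituted phenyl group or a 2-methoxyphenyl group on this nitrogen would read in this assay, and whether any group here gives a number well beyond the scatter from that of compound 2.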